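This account rests on a few compounds, and the source may have more. Where it says the series, first, only, none or still open, it means among the compounds named here.

Measured so far:
- compound 1 `Cc1ccc(Nc2nc3c(N4CCCC4)ncnc3s2)cc1` — 563 nM
- compound 2 `OC[C@@H]1CCCN1c1ncnc2sc(Nc3cccc(Br)c3)nc12` — 1070 nM

Both compounds were tested in an assay on CHO cells for displacement of a labelled ligand from adenosine receptor A3 (Homo sapiens), read by scintillation counting, with a stated time of 3 h; a lower number here means a stronger inhibitor, a higher number a weaker inhibitor. Compound 1 gives 563 nM in this assay, and compound 2 gives 1070 nM. Of the two numbers, that of compound 2 sits at the upper end, but the gap to compound 1 is within the usual scatter of repeated measurements, so the two cannot be told apart on this evidence.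

The next compound, compound 3 `Cc1ccc(Nc2nc3c(N4CCC[C@H]4CO)ncnc3s2)cc1`, differs from compound 2 in one place: 4-methylphenyl in place of 3-bromophenyl on a nitrogen on an aromatic ring. Among the compounds with values here, the rest of the shared core, including the pyrrolidine bearing a hydroxymethyl group, is kept from compound 2, while the 4-methylphenyl group is the one found in compound 1. Within the data shown here, no step between measured compounds isolates this change, so only the two values themselves give guidance. Because compound 1 with the 4-methylphenyl group gives 563 nM, a number at the lower end, compound 3 is expected to land close to it, with any step from compound 2 being small and downward at most, within the scatter. The expected step is a 1.5-fold lower number from compound 2 to compound 3 (0.18 log units; within the scatter). The estimate for compound 3 in this assay is 700 nM, with a range from 250 nM to 2000 nM.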

Compound 3, inhibition constant: 843 nM
Beside the measured number, compound 3's estimate is 1.2-fold (0.08 log units) below it; low and high end bracket the measured number.
By their numbers in this assay, from the lowest: compounds 1, 3 and 2 (each within the scatter of the next).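

Compounds 1 and 2 differ in two places, so their values could not show what either change does alone, whereas compound 3 separates the two changes. In this assay, putting 4-methylphenyl in place of 3-bromophenyl on the nitrogen gives a 1.3-fold lower number from compound 2 to compound 3 (0.10 log units; within the scatter) and so shows that, for this pair, the two aromatic groups cannot be told apart at this position. Hydroxymethyl in place of hydrogen on a saturated ring carbon gives a 1.5-fold higher number from compound 1 to compound 3 (0.18 log units; within the scatter) and so shows the same for that ring carbon, with neither step lying beyond the usual scatter, and no measurement shown here offers an explanation for either result.

The swap from 3-bromophenyl to 4-methylphenyl alters both the substituent and its place on the ring, so 3-methylphenyl or 4-bromophenyl would be needed to separate those two effects. From the compounds shown here alone, it also remains open whether an amine or a carboxylic acid on the aromatic ring, or a longer chain in place of hydroxymethyl, would give a step beyond the scatter.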